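This account rests on a few compounds, and the source may have more. Where it says the series, first, only, none or still open, it means among the compounds named here.

Measured so far in a functional assay on A549 cells (Homo sapiens) for antiproliferative activity, read by MTT assay, with a stated time of 72 h; a higher number here means a weaker inhibitor, a lower number a stronger inhibitor: compound 1 `C#Cc1cccc(Nc2ncnc3cc(OC)c(OCCCCC(=O)Nc4ccc(S(N)(=O)=O)cc4)cc23)c1` gives 7720 nM; compound 2 `COc1cc2ncnc(Nc3cccc(Cl)c3)c2cc1OCCCCC(=O)Nc1ccc(S(N)(=O)=O)cc1` gives 11200 nM. For compound 3 `COc1cc2ncnc(Nc3ccc(Cl)cc3)c2cc1OCCCCC(=O)Nc1ccc(S(N)(=O)=O)cc1` the assay reports only a limit, > 40000 nM.

Compound 3 therefore sits at the bound of this assay the limit of > 40000 nM in this assay, at which 1 of the 3 values shown sits, and is the weakest of the three on the numbers shown. The step to compound 4 `COc1cc2ncnc(Nc3ccc(F)c(Br)c3)c2cc1OCCCCC(=O)Nc1ccc(S(N)(=O)=O)cc1` is 3-bromo-4-fluorophenyl in place of 4-chlorophenyl on a nitrogen on an aromatic ring. Within the data shown here, two measured steps bear on it: an at least 3.5-fold higher number from compound 2 to compound 3 (0.55 log units; beyond the scatter) and an at least 5.1-fold higher number from compound 1 to compound 3 (0.71 log units; beyond the scatter), both beyond the scatter and both running from a 3-substituted phenyl to the 4-chlorophenyl. Compound 4 brings a 3-substituent back, so a lower number of about that size is expected, with the size uncertain since compound 3 is a limit. Compound 4 is expected at 12000 nM, range 4000 nM to 40000 nM, i.e. an expected at least 3.3-fold lower number from compound 3 to compound 4 (0.52 log units; beyond the scatter).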

Compound 4, half-maximal inhibitory concentration: 16000 nM
Compound 4: middle estimate off by 1.3-fold (0.12 log units), on the low side, within the range that was stated.
By their numbers in this assay, from the lowest: compounds 1, 2 and 4 (each within the scatter of the next, the first and the last beyond it). At a limit, above all of these: compound 3.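

In this assay, the change gives an at least 2.5-fold lower number from compound 3 to compound 4 (0.39 log units; beyond the scatter), which is a bound only, since one end of the step is a limit. A 4-halogen on the ring therefore does not by itself put a compound at that limit, as the 3-bromo-4-fluorophenyl group shows. The added 4-fluoro leaves no separable difference in a 1.4-fold higher number from compound 2 to compound 4 (0.15 log units; within the scatter), while a 2.1-fold higher number from compound 1 to compound 4 (0.32 log units; beyond the scatter) is a modest step.

From the compounds shown here alone, what remains open is how the bromo and fluoro groups contribute separately, which 3-bromophenyl and 4-fluorophenyl on the same nitrogen would show. Also open, going by these compounds, is how a longer chain in the linker would read here.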